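This account rests on a few compounds, and the source may have more. Where it says the series, first, only, none or still open, it means among the compounds named here.

Three compounds share one core and were tested in an assay on HEK293 cells for displacement of a labelled ligand from growth hormone secretagogue receptor type 1 (Homo sapiens), with a stated time of 60 min; a lower number here means a stronger inhibitor, a higher number a weaker inhibitor. Compound 1 `CN1CCN(CCCS(=O)(=O)c2ccc3nc(NC(=O)NC(=O)c4cc(-n5cccn5)c(Cl)cc4Cl)sc3c2)CC1` gives 0.31 nM. Compound 2 `CCOc1ccc(Cl)c(C(=O)NC(=O)Nc2nc3ccc(S(=O)(=O)CCCN4CCN(C)CC4)cc3s2)c1` gives 0.31 nM. Compound 3 `Cc1ccn(-c2ccc(Cl)c(C(=O)NC(=O)Nc3nc4ccc(S(=O)(=O)CCCN5CCN(C)CC5)cc4s3)c2)n1` gives 0.53 nM. Among these three numbers, compound 3 has the highest, yet its distance to compound 1 and to compound 2 is in each case within the scatter, so no order among them can be read. Within the data shown here, the one single-point step that was measured, a 1.7-fold higher number from compound 2 to compound 3 (0.23 log units; within the scatter), does not separate the two compounds either.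

Compound 4 `CN1CCN(CCCS(=O)(=O)c2ccc3nc(NC(=O)NC(=O)c4cc(-n5cccn5)ccc4Cl)sc3c2)CC1` is the unmeasured partner of compound 3. The change is hydrogen in place of methyl on an aromatic carbon. Among the measured compounds shown here, no measured step bears directly on this change: the step from compound 2 to compound 3 concerns a different group, and compound 1, which carries the 1H-pyrazol-1-yl group, differs from compound 4 in more than one place, so its value can only be set beside the others as it stands. With a small group leaving and no pattern to draw on, the step of a 1.2-fold lower number from compound 3 to compound 4 (0.07 log units; within the scatter) is expected to stay within the scatter, in no firm direction. Compound 4 is therefore estimated at 0.45 nM, with a range from 0.2 nM to 1.2 nM.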

Compound 4, half-maximal inhibitory concentration: 0.67 nM
The estimate for compound 4 lay 1.5-fold (0.17 log units) below the measured number; low and high end bracket the measured number.
By their numbers in this assay, from the lowest: compounds 1, 2, 3 and 4 (each within the scatter of the next, the first and the last beyond it).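

In this assay, taking the methyl off the 3-methyl-1H-pyrazol-1-yl group leaves no readable change (a 1.3-fold higher number from compound 3 to compound 4 (0.10 log units; within the scatter)), so on this aromatic carbon of the five-membered ring with 2 nitrogen, methyl and hydrogen cannot be told apart. Among these compounds, compound 4 also gives the first steps in this set that pass the scatter, both modest: a chloro group giving way to hydrogen (a 2.2-fold higher number from compound 1 to compound 4 (0.33 log units; beyond the scatter)) and 1H-pyrazol-1-yl in place of ethoxy on an aromatic carbon (a 2.2-fold higher number from compound 2 to compound 4 (0.33 log units; beyond the scatter)), which shows that the chloro and ethoxy positions register in this assay where the methyl position does not. No measurement at hand accounts for either of these steps.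

How an ethyl group, an amine or a carboxylic acid on this carbon of the pyrazole would read stays open, since methyl and hydrogen are the only two groups shown there. Also open, as far as these compounds go, is whether hydrogen in place of chloro would give a similar step with the 3-methyl-1H-pyrazol-1-yl group present, and the rest of the shared core is the same in all four compounds, so they say nothing about it.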